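The source may hold more compounds than are shown below. What is called first, only, known or untested is meant among the compounds shown, and "the series" means these compounds.

Three compounds in one family of growth hormone secretagogue receptor agonists have been tested. In a functional assay for agonist activity at growth hormone secretagogue receptor type 1 (Homo sapiens), read by FLIPR (a lower number here means that less compound is needed, a higher number that more compound is needed for the effect), compound 1 `C[C@@H]1CN(c2cc(NS(=O)(=O)c3ccc(-c4ccccn4)s3)ccc2C#N)C[C@H](C)N1` gives 631 nM, compound 2 `CC(=O)c1ccc(N2C[C@@H](C)N[C@@H](C)C2)cc1NS(=O)(=O)c1ccc(-c2ccccn2)s1` gives 39.8 nM, and compound 3 `COc1ccc(N2C[C@@H](C)N[C@@H](C)C2)cc1NS(=O)(=O)c1ccc(-c2ccccc2)cc1` gives 6.31 nM. Compound 3 stands lowest of the three; its nearest neighbour is compound 2, whose number is higher by a margin beyond the usual scatter, and compound 1 lies furthest away, also well beyond the scatter. Compound 3 is therefore the most potent of the measured set.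

Compound 4 `COc1ccc(N2C[C@@H](C)N[C@@H](C)C2)cc1NS(=O)(=O)c1ccc(-c2cc(Cl)ccc2F)cc1` has not yet been measured. It differs from compound 3 in one place: 5-chloro-2-fluorophenyl in place of phenyl on an aromatic carbon. Within the data shown here, no measured pair in this set shows what such a change does, so the expectation rests on compound 3 alone. The step from compound 3 to compound 4 is expected to be small, of the order of a 1.3-fold higher number from compound 3 to compound 4 (0.10 log units; within the scatter), and may fall within the scatter in either direction. Compound 4 is expected to give about 8 nM in this assay, within a range from 2 nM to 30 nM.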

Compound 4, half-maximal effective concentration: 0.501 nM
Estimate against measurement, compound 4: 16-fold (1.20 log units) above, and the stated range ends above it.
By their numbers in this assay, from the lowest: compound 4; then compound 3; then compound 2; then compound 1.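

In this assay, putting 5-chloro-2-fluorophenyl in place of phenyl on this aromatic carbon, para to a large group, gives a 13-fold lower number from compound 3 to compound 4 (1.10 log units; beyond the scatter). This shows that the group at this position strongly affects the number: the substituent grows only from 6 to 8 heavy atoms, with no hydrogen-bond donors, hydrogen-bond acceptors or net charge counted on either group, yet the step is large and lies beyond the scatter. No measurement shown here explains why the number falls.

The chlorine and the fluorine enter together, leaving open whether one alone would account for the step or whether both are needed. Also open, on these data alone, is how this assay would respond to a methoxy group, an amine or a carboxylic acid in place of the chlorine.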